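Removing a chloro from the core of compound 2

The compounds below may be only part of what the source reports. "The series", "measured", "known", "first", "only" and "open" are said of these compounds alone.

Measured compounds:
compound 1 `Nc1nc(Cl)c2ncn(Cc3ccc(CCl)cc3)c2n1` — 30900 nM
compound 2 `ClCc1ccccc1Cn1cnc2nc(Cl)nc(Cl)c21` — 20900 nM
compound 3 `ClCc1ccc(Cn2cnc3c(Cl)nc(Cl)nc32)cc1` — 29500 nM

In a functional assay on SK-OV-3 cells (Homo sapiens) for cytotoxicity, read by sulforhodamine B assay, with a stated time of 48 h (on this read-out lower numbers stand for stronger inhibition of growth and higher numbers for weaker inhibition of growth), compound 2 gives the lowest of the three numbers, though its gap to compound 3 and to compound 1 falls within the scatter. Compound 4 `ClCc1ccccc1Cn1cnc2ncnc(Cl)c21` is not yet measured; it differs from compound 2 in one place: hydrogen in place of chloro on an aromatic carbon. For the measured compounds named here, no measured step shows this exchange; the only step on record, a 1.0-fold lower number from compound 1 to compound 3 (0.02 log units; within the scatter), concerns another group and stayed within the scatter, so compound 4 is expected to sit close to compound 2, with no step beyond the scatter, a 1.1-fold higher number from compound 2 to compound 4 (0.06 log units; within the scatter). For compound 4 the estimate in this assay is 24000 nM, between 9000 nM and 65000 nM.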

Compound 4, concentration for total growth inhibition: 26900 nM
The estimate for compound 4 lay 1.1-fold (0.05 log units) below the measured number; low and high end bracket the measured number.
By their numbers in this assay, from the lowest: compounds 2, 4, 3 and 1 (each within the scatter of the next).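

In this assay, hydrogen in place of the chloro between two ring nitrogen atoms gives a 1.3-fold higher number from compound 2 to compound 4 (0.11 log units; within the scatter) and so leaves the number within the scatter. For the compounds shown here, this is the first reading of this exchange at this position, and it shows that, for this pair, the chloro there can go without a change beyond the scatter. No evidence at hand accounts for this result. The compounds shown leave open whether an amine or a methoxy group at this position would also stay within the scatter of compound 2. They also leave open whether losing the remaining chloro of compound 4 would matter more.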